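Tolerance of a Hydroxylated Allyl Chain in Lymphoma Cells

A few compounds are considered here, and "the series" means these few. Any claim that something is new, unique, unknown or untested is made for them only; others in the source may bear on it.

Compound 1, `COc1cc([C@H]2O[C@@H](c3cc(OC)c(OC)c(OC)c3)[C@H](C)[C@@H]2C)cc(OC)c1O`, gives 65800 nM.
Compound 2, `C=CCc1cc(OC)c(O[C@H](C)C(=O)c2cc(OC)c(OC)c(OC)c2)c(OC)c1`, gives > 200000 nM.

Both compounds were tested in an ADME assay on P3HR-1 cells (Homo sapiens) for cytotoxicity, read by microscopy and trypan blue exclusion, with a stated time of 2 days; a lower number here means that less compound is tolerated, a higher number that more compound is tolerated. Compound 1 gives a real number here, 65800 nM, so the cells stop tolerating it at a measurable concentration. Compound 2 is different: its result is a limit of the assay and not a number, and compound 2 therefore stands at the limit of > 200000 nM in this assay, at which 1 of the 2 values shown sits. In plain terms, no toxic concentration was reached for compound 2 within the tested range.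

Compound 3, `COc1cc(C(=O)[C@@H](C)Oc2c(OC)cc(/C=C/CO)cc2OC)cc(OC)c1OC`, has not yet been measured in this assay. It is built from compound 2 with a single change: 3-hydroxyprop-1-en-1-yl in place of allyl on an aromatic carbon. The chain keeps its length and its double bond, but an oxygen is added at the end, bringing a hydrogen-bond donor and acceptor where compound 2 has none.

For the measured compounds named here, no measured step between two compounds is available to guide an expectation for this change. With compound 2 already at the limit, the expected step is a number no higher from compound 2 to compound 3 (the limit leaves the size open), which means none beyond the usual scatter. Compound 3 is therefore estimated at 200000 nM, within a range from 90000 nM to 400000 nM.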

Compound 3, half-maximal cytotoxic concentration: > 200000 nM
Compound 3 ended at the assay's limit; the forecaster's own chance of this, stated with the estimate: 55%; the middle value sits exactly at the limit.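

No step can be read from compound 2 to compound 3, because in this assay each of the two results is a limit and not a number: the limit of > 200000 nM in this assay, at which 2 of the 3 values shown sit.

The compounds shown leave open whether 3-hydroxyprop-1-en-1-yl in place of allyl changes how well the cells tolerate compound 3, and at what concentration, if any, either compound turns toxic.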